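Stripping the Acetoxy Group from a Weakly Active Lactone

The source may hold more compounds than are shown below. What is called first, only, known or untested is meant among the compounds shown, and "the series" means these compounds.

Of the compounds shown here, three sharing the same small lactone core have been tested in a functional assay on B16 cells (Mus musculus) for cytotoxicity, read by MTT assay; on this read-out lower numbers stand for stronger inhibition and higher numbers for weaker inhibition. Compound 1 `CC(=O)CC[C@]1(C(C)=O)C(=O)O[C@@H](OC(C)=O)[C@H]1C` carries a 2-acetylethyl group on a saturated ring carbon, and in this assay compound 1 gives 7000 nM. Compound 2 `CC(=O)O[C@@H]1OC(=O)[C@@](C(C)=O)(C2SCCCS2)[C@@H]1C` reaches only a limit of the assay, giving > 50000 nM. Compound 3 `CC(=O)O[C@@H]1OC(=O)[C@](OC(C)=O)(C(C)=O)[C@@H]1C` likewise reaches only a limit, giving > 50000 nM. Both of these sit at the limit of > 50000 nM in this assay, at which 2 of the 3 values shown sit, so where compound 3 stands can be said only as a limit, not as a number. Compound 4 `CC(=O)O[C@@H]1OC(=O)[C@@H](C(C)=O)[C@@H]1C` has not yet been measured; it differs from compound 3 by hydrogen in place of acetoxy on a saturated ring carbon. The measured step that bears on this is an at least 7.1-fold higher number from compound 1 to compound 3 (0.85 log units; beyond the scatter), in which a longer chain was exchanged for acetoxy. The step that the two limits leave unreadable from compound 2 to compound 3 cannot be read. Taking the acetoxy away again leaves a smaller compound than any of the three, and this change is estimated to amount to an at least 1.6-fold lower number from compound 3 to compound 4 (0.22 log units; that floor lies within the scatter). Compound 4 is therefore expected to give 30000 nM, within a range from 5000 nM to 150000 nM.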

Compound 4, half-maximal inhibitory concentration: > 50000 nM
Compound 4 was reported as a limit; the forecaster's own chance of this, stated with the estimate: 55%; middle value at least 1.6-fold (0.22 log units) away from the limit.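

Compound 4 also stops at a limit of this assay, so hydrogen on this saturated ring carbon does no better than acetoxy, and the steps among compound 2, compound 3 and compound 4 cannot be read. Going by these compounds alone, the only readable new step is an at least 7.1-fold higher number from compound 1 to compound 4 (0.85 log units; beyond the scatter), which shows that a bare hydrogen here, like acetoxy, does not keep the measurable activity of compound 1 with its 2-acetylethyl group. So far only 2-acetylethyl at this position gives a number rather than a limit, and the other compounds share a single ceiling: the limit of > 50000 nM in this assay, at which 3 of the 4 values shown sit.

On these data alone, how far beyond that limit compound 2, compound 3 and compound 4 truly lie stays unknown. As far as these compounds go, it is also open whether a plain butyl chain or an amine at this carbon would give a measurable value, which would help show which part of 2-acetylethyl matters.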